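The compounds below may be only part of what the source reports. "The series", "measured", "known", "first", "only" and "open" are said of these compounds alone.

In a functional assay on B16 cells (Mus musculus) for cytotoxicity, read by MTT assay, with a stated time of 48 h (a lower number here means a stronger inhibitor, a higher number a weaker inhibitor), compound 1 (`C#CC1=CC[C@@]2(C)C(=C)CCC[C@]2(C)CC1`) gives 507000 nM, compound 2 (`C#CC1=CC[C@]2(CC1)C(=C)CC[C@H]2C(C)C`) gives 123000 nM, and compound 3 (`C=C1CCC[C@]2(C)CCC(c3cn(-c4ccc(I)cc4)nn3)=CC[C@@]12C`) gives 144000 nM. Compound 3 cannot be told apart from compound 2, since their values lie within the usual scatter, while its number is clearly lower than that of compound 1.

Compound 4 (`C=C1CCC[C@]2(C)CCC(c3cn(-c4ccc(Cl)cc4)nn3)=CC[C@@]12C`) departs from compound 3 in one place: chloro in place of iodo on an aromatic carbon. This puts chloro in place of iodo on an aromatic carbon, para to a large group, turning 4-iodophenyl into 4-chlorophenyl. Within the data shown here, no measured pair of compounds shows the effect of such an exchange, so the data favour neither direction, and no step beyond the scatter is expected in this assay. The expectation therefore rests on compound 3 at 144000 nM. The estimated step of a 1.0-fold higher number from compound 3 to compound 4 (0.02 log units; within the scatter) would stay within the scatter. Compound 4 is estimated at 150000 nM, with an expected range from 70000 nM to 300000 nM.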

Compound 4, half-maximal inhibitory concentration: 27200 nM
For compound 4 the middle estimate is 5.5-fold (0.74 log units) above the measured one; the whole stated range lies above it.
By their numbers in this assay, from the lowest: compound 4; then compounds 2 and 3 (each within the scatter of the next); then compound 1.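

On the phenyl ring of compound 3, the atom para to the large group proves to be no silent place: in this assay, chloro in place of iodo gives a 5.3-fold lower number from compound 3 to compound 4 (0.72 log units; beyond the scatter) and so moves the number beyond the scatter. This is the first step shown between compounds that differ in one place, and the exchange of one heavy atom, with no hydrogen-bond donor, acceptor or net charge entering or leaving, is enough to produce it. Nothing measured here bears on why the number falls.

With only iodo and chloro at this place, the compounds shown do not tell whether fluoro, bromo or a plain hydrogen would carry the number further or bring it back. Going by these compounds, how an amine, a methoxy group or a carboxylic acid would fare there also remains open.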